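This account rests on a few compounds, and the source may have more. Where it says the series, first, only, none or still open, it means among the compounds named here.

Measured so far:
Compound 1, `Cc1c(Cc2ccc(C(C)(C)C)cc2)c(=O)oc2cc(OCC(O)CN3CCC(C(N)=O)CC3)ccc12`: 14700 nM
Compound 2, `Cc1c(Cc2ccc(F)cc2F)c(=O)oc2cc(OCC(O)CN3CCC(C(N)=O)CC3)ccc12`: > 100000 nM

In an ADME assay on A549 cells (Homo sapiens) for cytotoxicity, read by CellTiter-Glo (a higher number here means that more compound is tolerated, a lower number that less compound is tolerated), compound 2 stands at a limit of the assay, > 100000 nM, rather than at a number; it is the limit of > 100000 nM in this assay, at which 1 of the 2 values shown sits. Compound 1 gives 14700 nM. The change to compound 3, `Cc1c(Cc2ccccc2C(F)(F)F)c(=O)oc2cc(OCC(O)CN3CCC(C(N)=O)CC3)ccc12`, is 2-(trifluoromethyl)phenyl in place of 2,4-difluorophenyl on a saturated chain carbon bound to an aromatic carbon. For the measured compounds named here, the one measured step, an at least 6.8-fold higher number from compound 1 to compound 2 (0.83 log units; beyond the scatter), also exchanged the group on the saturated chain carbon bound to an aromatic carbon and moved the number upward. For the new exchange a modest downward step is expected, with a fair chance of another limit. Compound 3 is expected to give 60000 nM, between 15000 nM and 150000 nM, a step of an at least 1.6-fold lower number from compound 2 to compound 3 (0.22 log units; that floor lies within the scatter).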

Compound 3, half-maximal cytotoxic concentration: > 100000 nM
Compound 3 was reported as a limit (the forecaster's own chance of this, stated with the estimate: 45%); at least 1.6-fold (0.22 log units) between middle value and limit.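

In this assay compound 3 gives > 100000 nM, a limit and not a number. The rise seen with 2,4-difluorophenyl is therefore not unique to that group, since 2-(trifluoromethyl)phenyl on the saturated chain carbon bound to an aromatic carbon gives an at least 6.8-fold higher number from compound 1 to compound 3 (0.83 log units; beyond the scatter). The step between compound 2 and compound 3 cannot be read, with both at the limit: the limit of > 100000 nM in this assay, at which 2 of the 3 values shown sit.

On these data alone, how far compound 2 and compound 3 lie past that limit stays open. So does whether a plain phenyl or a 4-methoxyphenyl group in this place would also reach it.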